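A few compounds are considered here, and "the series" means these few. Any claim that something is new, unique, unknown or untested is made for them only; others in the source may bear on it.

Compound 1 `O=C(Nc1cccc(-n2cc(-c3ccncc3)c(-c3cc(O)cc(Cl)c3)n2)c1)Nc1ccc(Cl)c(Cl)c1` has been measured in a functional assay on NCI-H226 cells (Homo sapiens) for inhibition, read by sulforhodamine B assay, with a stated time of 48 h, tested at 1 uM (on this read-out higher numbers stand for a weaker effect at the one concentration tested and lower numbers for a stronger effect), where compound 1 gives 96%. Among the three numbers measured so far, that is the highest, which on this read-out means the weakest effect at the single concentration tested. Compound 2 `COc1cc(Cl)cc(-c2nn(-c3cccc(NC(=O)Nc4ccc(Cl)c(C(F)(F)F)c4)c3)cc2-c2ccncc2)c1` gives in this assay a value of 79%, a lower number by a margin beyond the usual scatter, and compound 3 `COc1cc(Cl)cc(-c2nn(-c3cccc(NC(=O)Nc4cc(C(F)(F)F)cc(C(F)(F)F)c4)c3)cc2-c2ccncc2)c1` gives in this assay a value of 41%, lower still and also beyond the scatter. Compound 1 therefore stands as the weakest of the three.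

Compound 4 `COc1cc(Cl)cc(-c2nn(-c3cccc(NC(=O)Nc4ccc(Cl)c(Cl)c4)c3)cc2-c2ccncc2)c1` has not yet been measured. It differs from compound 1 in a single place: methyl in place of hydrogen on an oxygen on an aromatic ring. For the measured compounds named here, no pair of measured compounds differs in exactly this way, so the size of this step cannot be read off directly. Compounds 2 and 3 do carry the same methoxy group that enters in compound 4, but each of them also differs from compound 1 elsewhere, so their lower numbers point only loosely toward what compound 4 might do. A moderate drop in the number is expected, with the step from compound 1 to compound 4 estimated at a number 14 percentage points lower from compound 1 to compound 4 (beyond the scatter), partly because compound 2 gives 79%. Compound 4 is thus expected to give about 82%, with a likely range from 58% to 100%.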

Compound 4, a percentage reported as activity, at one concentration (the size of the read-out at that concentration, not a potency): 82%
Estimate against measurement, compound 4: no gap at the digits printed; low and high end bracket the measured number.
By their numbers in this assay, from the lowest: compound 3; then compounds 2 and 4 (each within the scatter of the next); then compound 1.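

In this assay, for the compounds shown here, this is the first direct reading at this position: going from hydroxy to methoxy on the 3-chloro-5-hydroxyphenyl group, with nothing else altered, gives a number 14 percentage points lower from compound 1 to compound 4 (beyond the scatter) and so a modest but real gain in effect at the one concentration tested. The compounds carrying the methoxy group can also now be compared with each other, and chloro in place of trifluoromethyl on an aromatic carbon gives a number 3 percentage points higher from compound 2 to compound 4 (within the scatter) so this swap on the other end of the molecule produces no readable change in this pair. Nothing measured alongside these numbers explains why the step at the oxygen has this size.

On these data alone, it remains open whether the gain belongs to methyl in particular or would also appear with an ethyl group, a longer chain on the oxygen, or an amine in place of the oxygen. Each number is a reading at one concentration. As far as these compounds go, how far compound 4 truly stands from compound 1 across a range of concentrations also remains open.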